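Moving a Fluorine Around the Phenyl Ring

The compounds below may be only part of what the source reports. "The series", "measured", "known", "first", "only" and "open" are said of these compounds alone.

Compound 1: `N#Cc1c(N2CCC(c3ccccc3Cl)CC2)ccn(CC2CC2)c1=O`, 49 nM
Compound 2: `COc1ccccc1C1CCN(c2ccn(CC3CC3)c(=O)c2C#N)CC1`, 35 nM
Compound 3: `N#Cc1c(N2CCC(c3ccc(F)cc3F)CC2)ccn(CC2CC2)c1=O`, 68 nM

In a functional assay on CHO cells for positive allosteric modulation of metabotropic glutamate receptor 2 (Homo sapiens), with a stated time of 30 min (on this read-out lower numbers stand for an effect already at smaller amounts and higher numbers for an effect only at larger amounts of compound), compound 3 gives the highest of the three numbers, yet each step towards it stays within the scatter: a 1.4-fold higher number from compound 1 to compound 3 (0.14 log units; within the scatter) and a 1.9-fold higher number from compound 2 to compound 3 (0.29 log units; within the scatter). The chloro and methoxy variants, compound 1 and compound 2, also lie within the scatter of each other, as a 1.4-fold lower number from compound 1 to compound 2 (0.15 log units; within the scatter) shows, so the three numbers cannot be ordered. Compound 4, `N#Cc1c(N2CCC(c3c(F)cccc3F)CC2)ccn(CC2CC2)c1=O`, keeps the shared core and differs from compound 3 only in the substituted phenyl on the saturated ring carbon: 2,6-difluorophenyl in place of 2,4-difluorophenyl on a saturated ring carbon. The measured steps that bear on this change are the two that alter the same phenyl ring, namely the step from compound 1 and the step from compound 2, and both were within the scatter. Compound 4 is therefore expected to show no step beyond the scatter in this assay, which in numbers means a 1.0-fold higher number from compound 3 to compound 4 (0.01 log units; within the scatter). The estimate for compound 4 is 70 nM, with a range from 30 nM to 160 nM.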

Compound 4, half-maximal effective concentration: 31 nM
For compound 4 the middle estimate is 2.3-fold (0.35 log units) above the measured one, and the stated range covers the measured number.
By their numbers in this assay, from the lowest: compounds 4, 2, 1 and 3 (each within the scatter of the next, the first and the last beyond it).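

Exchanging 2,4-difluorophenyl for 2,6-difluorophenyl on this saturated ring carbon leaves the atoms of the group unchanged, yet in this assay it gives a 2.2-fold lower number from compound 3 to compound 4 (0.34 log units; beyond the scatter). Among the compounds shown here, this is the first step beyond the scatter, and it shows that the arrangement of the two fluorines on the phenyl can register in the read-out, though only modestly, whereas the earlier steps at this carbon could not separate any of the groups. The 2,6-difluorophenyl group does not stand apart from the other two groups, as a 1.1-fold lower number from compound 2 to compound 4 (0.05 log units; within the scatter) and a 1.6-fold lower number from compound 1 to compound 4 (0.20 log units; within the scatter) both remain within the scatter, and nothing at hand explains why the two difluorophenyl groups differ.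

The compounds shown leave open whether two fluorines are needed at all, since none of them has a phenyl carrying one fluorine alone or a plain phenyl on this carbon. They also leave open how this carbon would respond to a phenyl bearing an amine or a carboxylic acid, and whether the gap between the two difluorophenyl groups would persist with a different group on the ring nitrogen of the shared core.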